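The source may hold more compounds than are shown below. What is called first, only, known or untested is meant among the compounds shown, and "the series" means these compounds.

Compound 1 `C=CCCCCCCCC#CC#C/C=C\C(C)=O` is a long hydrocarbon chain that carries a vinyl group at one end, two conjugated triple bonds and a methyl ketone at the other end. In a functional assay on HCT-15 cells (Homo sapiens) for cytotoxicity (a lower number here means that less compound is needed, a higher number that more compound is needed for the effect), compound 1 gave only a limit, > 50 ug/mL, so no number is known for it. Compound 2 `CCCCCCCC#CC#C/C=C\C(C)=O` is the same chain with hydrogen in place of vinyl on a saturated chain carbon, seven bonds along the chain from a triple-bonded carbon. In this assay compound 2 likewise gave only a limit, > 50 ug/mL. The step that the two limits leave unreadable from compound 1 to compound 2 therefore has no readable size, because both measurements sit at the limit of > 50 ug/mL in this assay, at which 2 of the 2 values shown sit.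

Compound 3 `C=CCCCCCCCC#CC#C/C=C/C(C)=O` is related to compound 1 as the two compounds have the same atoms and bonds and differ only in configuration as drawn: 1 of 1 stereo elements differ; a double bond is drawn Z in compound 1 and E in compound 3. Among the measured compounds shown here, neither measured step concerns the geometry of this double bond, and the single measured step is itself unreadable, so there is no guide to the direction or size of this change. What the two measured compounds share is that both reached only the limit of this assay.

On that basis, compound 3 is expected to sit at or near the limit as well, with an estimated value of 80 ug/mL and a range from 30 ug/mL to 250 ug/mL. The step that the limit leaves unreadable from compound 1 to compound 3 is thus expected to be no larger than the ordinary scatter.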

Compound 3, concentration for half-maximal effect: 5.2 ug/mL
Compound 3: the middle estimate sits 15-fold (1.19 log units) above what was measured; the whole stated range lies above it.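

Among the compounds shown here, changing a double bond drawn Z in compound 1 to one drawn E in compound 3 gives an at least 9.6-fold lower number from compound 1 to compound 3 (0.98 log units; beyond the scatter) in this assay, which makes this the first readable step and places it beyond the usual scatter. No atom or bond enters or leaves, so this step can be assigned to the geometry of that one double bond: the fact that compounds 1 and 3 differ only in the configuration as drawn. The true gap could be larger than the printed figure, because compound 1 rests at a limit rather than at a measured number: the limit of > 50 ug/mL in this assay, at which 2 of the 3 values shown sit.

Going by these compounds, the step from compound 1 to compound 2 cannot be read, so it remains open whether removing the vinyl group would change the number for a compound with the double bond drawn E, as in compound 3. On these data alone, it is also open how much the methyl ketone contributes to the effect of compound 3, and a carboxylic acid or an amide in its place would be one way to explore this.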